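The source may hold more compounds than are shown below. What is called first, only, known or untested is meant among the compounds shown, and "the series" means these compounds.

Of the compounds shown here, two sharing one core have been measured in a functional assay on HFF cells (Homo sapiens) for cytotoxicity; on this read-out higher numbers stand for weaker inhibition and lower numbers for stronger inhibition. Compound 1 `CSc1nc(N)c2ccn(COCCO)c2n1` carries a methylsulfanyl group on an aromatic carbon. In this assay compound 1 gives > 100000 nM, which is a limit of the assay rather than a number. Compound 2 `COc1nc(N)c2ccn(COCCO)c2n1` has a methoxy group in place of that methylsulfanyl. In this assay compound 2 gives > 100000 nM, again a limit of the assay and not a number. The step from compound 1 to compound 2 a step that the two limits leave unreadable from compound 1 to compound 2 therefore cannot be read, since both values sit at the limit of > 100000 nM in this assay, at which 2 of the 2 values shown sit. Compound 2 thus stands at the limit, with no number to place it anywhere beneath it.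

Compound 3 `Nc1nc(O)nc2c1ccn2COCCO` is the next step: hydrogen in place of methyl on an oxygen on an aromatic ring, so the methoxy becomes a hydroxy group. For the measured compounds named here, the one measured step bears on this change only loosely, and its size is unreadable because of the limit of > 100000 nM in this assay, at which 2 of the 2 values shown sit. Nothing measured points to a move in either direction. Compound 3 is expected to remain at the limit, so the step from compound 2 to compound 3 is estimated as a number no higher from compound 2 to compound 3 (the limit leaves the size open). The estimate for compound 3 in this assay is 100000 nM, ranging from 40000 nM to 300000 nM, most likely reported only as a limit.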

Compound 3, half-maximal inhibitory concentration: > 100000 nM
Compound 3 gave a limit, no number; the forecaster's own chance of this, stated with the estimate: 85%; the middle value sits exactly at the limit.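

Compound 3 gives > 100000 nM in this assay, which is a limit of the assay and not a number. For the compounds shown here, no step among compound 1, compound 2 and compound 3 can therefore be read: the limit of > 100000 nM in this assay, at which 3 of the 3 values shown sit. The compounds shown leave open how the three would rank, and at what concentration, if any, each would reach half-maximal inhibition.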